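A Chloro Substituent Added to the Best Sulfonamide So Far

The source may report more compounds than this note shows. Statements on the series, on what has been measured and on what is new or still open speak of the compounds shown alone.

Compound 1 `Cc1c(S(=O)(=O)N[C@H]2CCN(Cc3cc4c[nH]ccc-4n3)C2=O)sc2ccc(Cl)cc12` — 37%
Compound 2 `O=C1[C@@H](NS(=O)(=O)c2cc3ncccc3s2)CCN1Cc1cc2c[nH]ccc-2n1` — 61%
Compound 3 `O=C1[C@@H](NS(=O)(=O)c2ccc(-c3ccc(Cl)s3)s2)CCN1Cc1cc2[nH]cccc-2n1` — 42%

Of the compounds shown here, three have been measured in an assay on isolated protein for inhibition of coagulation factor X (Oryctolagus cuniculus), tested at 1 uM; on this read-out higher numbers stand for more inhibition at the one concentration tested (going by the name of the read-out) and lower numbers for less inhibition. Among them compound 2 stands highest with 61%. Its nearest neighbour is compound 3, whose value of 42% lies a gap beyond the usual scatter below it, and the furthest is compound 1, whose value of 37% lies still further below, also beyond the scatter. Among the compounds with values here, no pair of these three differs in only one place, so no single structural step can be read directly from them.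

Compound 4 `O=C1[C@@H](NS(=O)(=O)c2cc3nc(Cl)ccc3s2)CCN1Cc1cc2c[nH]ccc-2n1` is the next candidate. It differs from compound 2 in one place: chloro in place of hydrogen on an aromatic carbon. Within the data shown here, since no comparable step between measured compounds is available, the expectation rests on compound 2 alone. The step is estimated to be small, a number 1 percentage points lower from compound 2 to compound 4 (within the scatter), that is, no change beyond the scatter in either direction. On that basis compound 4 is expected to give about 60%, within a range of 35% to 80%.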

Compound 4, a percentage reported as inhibition, at one concentration (the size of the read-out at that concentration, not a potency): 58%
The estimate for compound 4 lay 2 percentage points above the measured number, and the stated range covers the measured number.
By their numbers in this assay, from the lowest: compounds 1 and 3 (each within the scatter of the next); then compounds 4 and 2 (each within the scatter of the next).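

Within the data shown here, the step of a number 3 percentage points lower from compound 2 to compound 4 (within the scatter) is the first comparison in this set that can be read in one place, and it shows that in this assay chloro can take the place of hydrogen on this aromatic carbon, next to the ring nitrogen, without a change beyond the scatter. The earlier compounds shown here, none of which differ in only one place, could not show that this position accepts a chlorine atom while the inhibition at the one concentration tested stays within the scatter. No measurement here bears on why the number holds.

The compounds shown leave open whether an amine, a methoxy group or a carboxylic acid at this same position would also keep the number within the scatter of compound 2. They also leave open whether chloro on the other carbons of this ring would do the same.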